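Chloro in Place of Bromo, Second Time Around

This account rests on a few compounds, and the source may have more. Where it says the series, first, only, none or still open, it means among the compounds named here.

Of the compounds shown here, three built on one shared core have been measured in a functional assay on A-375 cells (Homo sapiens) for antiproliferative activity, read by MTT assay, with a stated time of 48 h; a higher number here means a weaker inhibitor, a lower number a stronger inhibitor. Compound 1 `Cc1ccc(-c2cc(NC(=O)c3ccc(Br)nc3)n[nH]2)cc1` gives 7670 nM. Compound 2 `Cc1ccc(-c2cc(NC(=O)c3ccc(Cl)nc3)n[nH]2)cc1` differs from compound 1 only in chloro in place of bromo on an aromatic carbon, and in this assay compound 2 gives 6880 nM, which is a 1.1-fold lower number from compound 1 to compound 2 (0.05 log units; within the scatter). Compound 3 `O=C(Nc1cc(-c2ccc(Br)cc2)[nH]n1)c1ccc(Br)nc1` differs from compound 1 in another part of the shared core, by bromo in place of methyl on an aromatic carbon. In this assay compound 3 gives 9910 nM, which is a 1.3-fold higher number from compound 1 to compound 3 (0.11 log units; within the scatter). All three numbers lie within the scatter of one another, so no ranking among them can be read from these data.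

Compound 4 `O=C(Nc1cc(-c2ccc(Br)cc2)[nH]n1)c1ccc(Cl)nc1` has not yet been measured. It differs from compound 3 by chloro in place of bromo on an aromatic carbon, the same change that separates compound 1 from compound 2, made at the same place on the same kind of ring. That earlier step, a 1.1-fold lower number from compound 1 to compound 2 (0.05 log units; within the scatter), lay within the scatter, and the core of compound 3 differs from the core of compound 1 only as described above, so the expectation rests on a single prior example. Resting on compound 3 at 9910 nM and on the earlier step of a 1.1-fold lower number from compound 1 to compound 2 (0.05 log units; within the scatter), the expected step for compound 4 is a 1.1-fold lower number from compound 3 to compound 4 (0.04 log units; within the scatter). The estimate for compound 4 in this assay is 9000 nM, expected to fall between 5000 nM and 16000 nM.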

Compound 4, half-maximal inhibitory concentration: 8890 nM
For compound 4 the middle estimate is 1.0-fold (0.01 log units) above the measured one; low and high end bracket the measured number.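

In this assay, chloro in place of bromo gives a 1.1-fold lower number from compound 3 to compound 4 (0.05 log units; within the scatter), and this step matches the one seen earlier on the other core: the same change on two cores in this assay, a 1.1-fold lower number (0.05 log units; within the scatter) from compound 1 to compound 2 and a 1.1-fold lower number (0.05 log units; within the scatter) from compound 3 to compound 4, 1.0-fold (0.00 log units) apart, within the scatter of two such steps. Bromo in place of methyl, read on the chloro side of the series, gives a 1.3-fold higher number from compound 2 to compound 4 (0.11 log units; within the scatter), and it likewise matches its earlier counterpart: the same change on two cores in this assay, a 1.3-fold higher number (0.11 log units; within the scatter) from compound 1 to compound 3 and a 1.3-fold higher number (0.11 log units; within the scatter) from compound 2 to compound 4, 1.0-fold (0.00 log units) apart, within the scatter of two such steps. Both changes therefore behave alike on the two cores compared here, but since every step lies within the scatter, what carries over is only the lack of a readable difference, and the data show neither that these changes shift the antiproliferative reading nor that a step of real size would transfer from one core to another.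

The compounds shown carry only bromo or chloro at one place and only methyl or bromo at the other, and all four numbers stay within a narrow span, so nothing yet tests transfer with a step beyond the scatter. From the compounds shown here alone, it remains open whether an amine or a carboxylic acid in place of the halogen, or a longer chain in place of the methyl, would give such a step, and whether that step would hold on both cores.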